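A few compounds are considered here, and "the series" means these few. Any claim that something is new, unique, unknown or untested is made for them only; others in the source may bear on it.

In a functional assay on HeLa cells (Homo sapiens) for antiproliferative activity, read by MTT assay, with a stated time of 72 h (on this read-out higher numbers stand for weaker inhibition and lower numbers for stronger inhibition), compound 1 (`CNc1nc(-c2cc(OC)c(OC)c(OC)c2)c(-c2ccc(OC)cc2)s1`) gives 70.1 nM, compound 2 (`COc1ccc(-c2sc(N(C)C)nc2-c2cc(OC)c(OC)c(OC)c2)cc1`) gives 3370 nM, and compound 3 (`COc1cc(-c2nc(C)sc2-c2ccc(C(F)(F)F)cc2)cc(OC)c1OC`) gives 3830 nM. Compound 3 therefore stands level with compound 2, within the usual scatter, and both numbers lie well above that of compound 1.

Compound 4 (`COc1ccc(-c2sc(C)nc2-c2cc(OC)c(OC)c(OC)c2)cc1`) differs from compound 3 by a single change: methoxy in place of trifluoromethyl on an aromatic carbon. This is methoxy in place of trifluoromethyl on an aromatic carbon.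

For the measured compounds named here, the only measured step, a 48-fold higher number from compound 1 to compound 2 (1.68 log units; beyond the scatter), involves a nitrogen rather than this carbon, so it does not measure the change directly. It shows only that one small change can matter greatly among these compounds. Compound 4 shares its methoxy with compound 1 at 70.1 nM, but also with compound 2 at 3370 nM, so the group alone does not settle the number. A moderately lower number than for compound 3 is expected, with wide uncertainty. The estimate for compound 4 is 500 nM, with an expected range from 90 nM to 2800 nM. The expected change is a 7.7-fold lower number from compound 3 to compound 4 (0.88 log units; beyond the scatter).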

Compound 4, half-maximal inhibitory concentration: 500 nM
Compound 4: the middle estimate sits on the measured number at the digits printed; low and high end bracket the measured number.
By their numbers in this assay, from the lowest: compound 1; then compound 4; then compounds 2 and 3 (each within the scatter of the next).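

Trifluoromethyl and methoxy can now be compared directly on this aromatic carbon: methoxy in place of trifluoromethyl gives a 7.7-fold lower number from compound 3 to compound 4 (0.88 log units; beyond the scatter). With methoxy held fixed, the group at the other site on the shared core also moves the number: methyl in place of dimethylamino gives a 6.7-fold lower number from compound 2 to compound 4 (0.83 log units; beyond the scatter), whereas methyl in place of methylamino gives a 7.1-fold higher number from compound 1 to compound 4 (0.85 log units; beyond the scatter). Methoxy therefore helps in this comparison but does not set the number alone, and among the three methoxy compounds the methyl compound falls between the methylamino and dimethylamino compounds.

No measured evidence here explains any of these steps. The compounds shown also leave open how a hydroxyl group or a chlorine atom would compare on this aromatic carbon, and how an unsubstituted amino group would compare in place of methyl.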